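This account rests on a few compounds, and the source may have more. Where it says the series, first, only, none or still open, it means among the compounds named here.

The measured compounds:
Compound 1 `CN(C)CCn1cnnc1-c1cc(Oc2ccc(NC(=O)N/N=C/c3ccc(O)c(Br)c3)cc2F)ccn1` gives 1370 nM in a functional assay on A549 cells (Homo sapiens) for cytotoxicity, read by MTT assay, with a stated time of 72 h; on this read-out higher numbers stand for weaker inhibition and lower numbers for stronger inhibition.
Compound 2 `COc1cc(/C=N/NC(=O)Nc2ccc(Oc3ccnc(-c4nncn4CCN(C)C)c3)c(F)c2)cc(OC)c1OC` reaches only a limit of the assay in this assay: > 100000 nM.

Among the compounds with values here, compound 1 therefore holds the only real number in this set; the other value shown is a limit. The compound to be considered is compound 3 `COc1cc(/C=N/NC(=O)Nc2ccc(Oc3ccnc(-c4nncn4CCN(C)C)c3)c(F)c2)ccc1O`. Compared with compound 1 the change is methoxy in place of bromo on an aromatic carbon. The hydroxy group stays in place, and the change is confined to the group standing ortho to it.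

Within the data shown here, one measured step bears on this. The move from compound 1 to compound 2 exchanges 3-bromo-4-hydroxyphenyl for 3,4,5-trimethoxyphenyl and gives an at least 72-fold higher number from compound 1 to compound 2 (1.86 log units; beyond the scatter), with compound 2 sitting at the limit of > 100000 nM in this assay, at which 1 of the 2 values shown sits. Among the measured compounds shown here, that step removes the hydroxy group as well as the bromo and adds three methoxy groups, so it is a larger alteration than the one leading to compound 3. A step toward a higher number in this assay, but a much smaller one than the step to compound 2, is anticipated here. For compound 3 the expected step is estimated as a 2.9-fold higher number from compound 1 to compound 3 (0.47 log units; beyond the scatter). Compound 3 is thus estimated at 4000 nM, within a range of 1500 nM to 20000 nM.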

Compound 3, half-maximal inhibitory concentration: > 100000 nM
Compound 3 ended at the assay's limit; the forecaster's own chance of this, stated with the estimate: 15%; middle value at least 25-fold (1.39 log units) away from the limit.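

In this assay, methoxy in place of bromo on the aromatic carbon ortho to the hydroxy group gives an at least 72-fold higher number from compound 1 to compound 3 (1.86 log units; beyond the scatter). The earlier step to compound 2 altered several groups at once, whereas this one shows that a change at this single position, with the hydroxy group kept, is enough to lose any measurable value, and that the hydroxy group alone does not secure one in this series. The values of compound 2 and compound 3 are both limits and not numbers, so the step from one to the other cannot be read: the limit of > 100000 nM in this assay, at which 2 of the 3 values shown sit.

The compounds shown leave open whether a measurable value at this position depends on bromo itself or would also hold with another small group such as chloro, methyl or an amine. Within the data shown here, they also leave open how methoxy in place of the hydroxy group would act with bromo kept, as compound 1 remains the only compound here with a real number.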